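The source may report more compounds than this note shows. Statements on the series, on what has been measured and on what is new or still open speak of the compounds shown alone.

Compound 1 `Cc1ccc(/C=C/C=C2\CCC=CC2=O)cc1`: 8600 nM
Compound 2 `O=C1C=CCC/C1=C\C=C\c1ccc([N+](=O)[O-])cc1`: 4900 nM

In a functional assay on HepG2 cells (Homo sapiens) for cytotoxicity, read by MTT assay, with a stated time of 72 h (on this read-out higher numbers stand for weaker inhibition and lower numbers for stronger inhibition), compound 2 gives 4900 nM. Among the compounds with values here, it cannot be ranked against the only other compound measured, since the single step available is a 1.8-fold lower number from compound 1 to compound 2 (0.24 log units; within the scatter). The two compounds therefore stand level on these numbers.

Compound 3 `CC(=O)Oc1ccc(/C=C/C=C2\CCC=CC2=O)cc1` keeps the shared core and alters one group, with acetoxy in place of nitro on an aromatic carbon, para to a large group (acetoxy in place of nitro on an aromatic carbon). Within the data shown here, no compound carrying acetoxy has been measured yet, so the evidence is thin. Among the measured compounds shown here, the one measured step bears on this change. It exchanged the group at the same place, and that exchange gave a 1.8-fold lower number from compound 1 to compound 2 (0.24 log units; within the scatter). One step cannot establish a rule, but it offers no reason to expect a step beyond the scatter in this assay, in either direction. The step expected here is a 1.3-fold higher number from compound 2 to compound 3 (0.12 log units; within the scatter). The estimate for compound 3 is 6500 nM, with an expected range from 2500 nM to 16000 nM.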

Compound 3, half-maximal inhibitory concentration: 4500 nM
The estimate for compound 3 lay 1.4-fold (0.16 log units) above the measured number, within the range that was stated.
By their numbers in this assay, from the lowest: compounds 3, 2 and 1 (each within the scatter of the next).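

Within the data shown here, compound 3 brings a third kind of group to this place on the aromatic ring, para to a large group, and this assay still shows no step that can be told from the scatter. Acetoxy in place of nitro gives a small step (a 1.1-fold lower number from compound 2 to compound 3 (0.04 log units; within the scatter)), and acetoxy in place of methyl gives another that stays within the scatter (a 1.9-fold lower number from compound 1 to compound 3 (0.28 log units; within the scatter)), so methyl, nitro and acetoxy all stand level here, and two single exchanges at this place have become three compounds that agree. Nothing beyond these cytotoxicity numbers is available to explain this agreement.

Going by these compounds, it remains open whether an amine, a carboxylic acid or a longer chain at this same place would give a step beyond the scatter, since such a group would differ from methyl, nitro and acetoxy in kind. On these data alone, it is equally open whether a change elsewhere on the aromatic ring, or in the shared core, would move the number more than any exchange of this group has so far.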